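This account rests on a few compounds, and the source may have more. Where it says the series, first, only, none or still open, it means among the compounds named here.

Working notes on the series. In an ADME assay on cells (Homo sapiens) for cytotoxicity, read by sulforhodamine B assay, with a stated time of 48 h (on this read-out higher numbers stand for an effect only at larger amounts of compound and lower numbers for an effect already at smaller amounts), compound 1 (`CN(C)c1ccc(/C=C2/SC(=Nc3ccccc3)NC2=O)cc1`) gives > 100000 nM, which is a limit of the assay and not a number. Compound 2 (`CCN(CC)c1ccc(/C=C2/SC(Nc3ccccc3)=NC2=O)cc1`) gives > 100000 nM, again a limit. Compound 3 (`CN(C)c1ccc(/C=C2/SC(N(c3ccccc3)c3ccccc3)=NC2=O)cc1`) gives > 100000 nM, also a limit, so its standing is known only in that form. The whole set stands at the limit of > 100000 nM in this assay, at which 3 of the 3 values shown sit.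

The next compound is compound 4 (`CN1CCN(c2ccc(/C=C3/SC(N(c4ccccc4)c4ccccc4)=NC3=O)cc2)CC1`). It carries 4-methylpiperazin-1-yl in place of the dimethylamino of compound 3, on an aromatic carbon, para to a large group: 4-methylpiperazin-1-yl in place of dimethylamino on an aromatic carbon.

Within the data shown here, no measured step between compounds differing in one place is available, so the series gives no direct size for this kind of change. The only anchor for an expectation is the limit of > 100000 nM in this assay, at which 3 of the 3 values shown sit. A further limit is therefore the most likely outcome, with a smaller chance of a real number at the lower side. The expected step of a number no higher from compound 3 to compound 4 (the limit leaves the size open) stays within the usual scatter, and any real movement is expected towards lower numbers in this assay. For compound 4 the expected value is 100000 nM, with an estimated range from 30000 nM to 300000 nM.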

Compound 4, half-maximal effective concentration: > 100000 nM
Compound 4: only a limit was reported; the forecaster's own chance of this, stated with the estimate: 70%; the middle value sits exactly at the limit.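

Compound 3 and compound 4 are both reported only as limits in this assay, so no step can be read between them. The compounds shown leave open whether 4-methylpiperazin-1-yl in place of dimethylamino on an aromatic carbon changes the read-out at all, and which change to the shared core would give a real number.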